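The compounds below may be only part of what the source reports. "The series", "measured", "known", "first", "only" and "open" are said of these compounds alone.

Working notes on the series. For the measured compounds named here, compound 2 (`Clc1cccc(-n2ncnc2NCc2ccccc2)c1Cl`) gives 209 nM in a functional assay for antagonist activity at P2X purinoceptor 7 (Rattus norvegicus), read by FLIPR and calcium flux (a higher number here means a weaker inhibitor, a lower number a stronger inhibitor), and stands lowest of the three numbers so far. Compound 1 (`Clc1cccc(-n2ncnc2Nc2ccccc2)c1Cl`) gives 3890 nM in this assay, and the step from compound 1 to compound 2 is a 19-fold lower number from compound 1 to compound 2 (1.27 log units; beyond the scatter). Compound 3 (`COc1ccccc1CNc1ncnn1-c1cccc(Cl)c1Cl`) gives 708 nM in this assay; the step from compound 2 to compound 3 is a 3.4-fold higher number from compound 2 to compound 3 (0.53 log units; beyond the scatter).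

Compound 4 (`COc1cccc(CNc2ncnn2-c2cccc(Cl)c2Cl)c1`) has not been measured. Relative to compound 2 the change is methoxy in place of hydrogen on an aromatic carbon. The one measured step that bears on it is the methoxy addition from compound 2 to compound 3, which was modest and in the direction of a higher number; compound 4 carries the same group on the same ring, at the place described above rather than where compound 3 carries it, so no further step speaks to that difference. The large step from compound 1 to compound 2 concerns benzyl against phenyl and does not bear on the methoxy.

For compound 4 a modest step toward a higher number than compound 2 is expected, around a 2.2-fold higher number from compound 2 to compound 4 (0.33 log units; beyond the scatter), and the estimate is 450 nM with a range from 150 nM to 1300 nM.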

Compound 4, half-maximal inhibitory concentration: 1380 nM
Estimate against measurement, compound 4: 3.1-fold (0.49 log units) below; the whole stated range lies below it.
By their numbers in this assay, from the lowest: compound 2; then compounds 3 and 4 (each within the scatter of the next); then compound 1.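

In this assay, methoxy meta to a large group gives a 6.6-fold higher number from compound 2 to compound 4 (0.82 log units; beyond the scatter), so the rise in the number seen for compound 3 is not confined to one placement of this group on the ring. Compounds 3 and 4 stand within the scatter of each other, so the two placements cannot be told apart in this assay, although each of them lies beyond the scatter from compound 2, the unsubstituted benzyl compound. No measured property of these compounds accounts for the effect of methoxy at either place. 

Whether any group on this ring can match or improve on compound 2 stays open, since the compounds shown carry only methoxy there and say nothing of a fluorine, a methyl, a hydroxyl or an amine at the same place. Also open, from the compounds shown here alone, is whether a longer chain such as phenethyl in place of benzyl would extend the gain seen in a 19-fold lower number from compound 1 to compound 2 (1.27 log units; beyond the scatter) or reverse it.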